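A few compounds are considered here, and "the series" means these few. Any claim that something is new, unique, unknown or untested is made for them only; others in the source may bear on it.

Working notes on the series. Compound 1 `Cc1cc(C)cc(Cn2cc(C(=O)/C=C(\O)C(=O)O)c3cc(Cl)ccc32)c1` is recorded in an ADME assay on MT4 cells (Homo sapiens) for cytotoxicity, read by MTT assay (on this read-out lower numbers stand for higher toxicity in this test and higher numbers for lower toxicity in this test), only as a limit, > 125000 nM, not as a number (the limit of > 125000 nM in this assay, at which 1 of the 3 values shown sits). Compound 2 `Cc1cc(C)c(Cn2cc(C(=O)/C=C(\O)C(=O)O)c3cc(F)ccc32)c(C)c1` gives 104000 nM in this assay, and compound 3 `COc1ccc2c(c1)c(C(=O)/C=C(\O)C(=O)O)cn2Cc1c(C)cc(C)cc1C` gives 23500 nM. Among the measured compounds shown here, the single step between measured compounds, a 4.4-fold lower number from compound 2 to compound 3 (0.65 log units; beyond the scatter), concerns a substituent on an aromatic carbon. Compound 4 `Cc1cc(C)cc(Cn2cc(C(=O)C3=C(O)C(=O)OC3)c3cc(Cl)ccc32)c1` differs from compound 1 in another place: a group of 7 heavy atoms (4 carbon, 3 oxygen; one five-membered non-aromatic ring with 1 hetero atom) in place of a group of 6 heavy atoms (3 carbon, 3 oxygen; no ring), on a carbonyl carbon. For the measured compounds named here, no measured step touches that carbonyl carbon, so the one step at hand does not bear on the change, and no shift beyond the scatter is assumed in this assay. Near the limit seen for compound 1, compound 4 is therefore expected at 130000 nM, with a range of 40000 nM to 400000 nM, an expected step that the limit leaves unreadable from compound 1 to compound 4.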

Compound 4, half-maximal cytotoxic concentration: 53500 nM
Beside the measured number, compound 4's estimate is 2.4-fold (0.39 log units) above it; measured number inside the range.
By their numbers in this assay, from the lowest: compound 3; then compounds 4 and 2 (each within the scatter of the next). At a limit, above all of these: compound 1.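

Among the compounds shown here, on the carbonyl carbon, where no earlier step reached, replacing 2-carboxy-2-hydroxyethenyl with the group bearing a five-membered non-aromatic ring is not neutral in this assay: the result is an at least 2.3-fold lower number from compound 1 to compound 4 (0.36 log units; beyond the scatter). The change therefore moves toward higher toxicity in this test, and the size of the step is only a minimum. The entry for compound 1 is a limit: the limit of > 125000 nM in this assay, at which 1 of the 4 values shown sits.

On these data alone, whether the same exchange gives a similar step with the fluoro or methoxy substituents of compound 2 and compound 3 remains open. So does the reading of a primary amide or a tetrazole on that carbonyl carbon.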